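Quinolinone series: cytotoxicity on HCT-15, carboxy extension

This account rests on a few compounds, and the source may have more. Where it says the series, first, only, none or still open, it means among the compounds named here.

Measured compounds:
compound 1 `COc1cccc2cc(-c3ccccc3)c(O)nc12` — 10000 nM
compound 2 `COc1cc(OC)c2cc(-c3ccc(OCc4ccccc4)cc3)c(O)nc2c1` — 10000 nM
compound 3 `COc1ccc(-c2cc3c(OC)cc(OC)cc3n(C)c2=O)cc1` — 10000 nM

In a functional assay on HCT-15 cells (Homo sapiens) for cytotoxicity, read by colorimetric assay and MTT assay (on this read-out higher numbers stand for weaker inhibition and lower numbers for stronger inhibition), compound 1, compound 2 and compound 3 all sit at the same value; compound 3 is level with both, the gaps lying within the scatter. No difference among the three at the digits shown, so the numbers give no direction to build on.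

Compound 4 `COc1ccc(-c2cc3c(OC)cc(OC)cc3n(CC(=O)O)c2=O)cc1` is the next member. It differs from compound 3 by carboxy in place of hydrogen on a saturated chain carbon bound to an aromatic nitrogen. Within the data shown here, nothing among the measured compounds tests this kind of change, so no step beyond the scatter is expected in this assay. Compound 4 is estimated at 10000 nM, range 5000 nM to 20000 nM. The expected step of no change at the digits printed from compound 3 to compound 4 (within the scatter) is thus none beyond the scatter.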

Compound 4, half-maximal inhibitory concentration: 10000 nM
For compound 4 middle estimate and measured number coincide at the digits printed, and the stated range covers the measured number.
By their numbers in this assay, from the lowest: compounds 1, 2, 3 and 4 (each within the scatter of the next).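

Carboxy in place of hydrogen on a saturated chain carbon bound to an aromatic nitrogen gives no change at the digits printed from compound 3 to compound 4 (within the scatter) in this assay. Among these compounds, this is the first comparison that differs in one place, and methyl to carboxymethyl at this position leaves the read-out without a step beyond the scatter. No evidence at hand bears on this result.

Open, as far as these compounds go, is whether a methyl ester, a primary amide or an aminoethyl chain at this place would give a step beyond the scatter. From the compounds shown here alone, a longer chain ending in the same carboxy group is equally open.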